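The source may hold more compounds than are shown below. What is called first, only, known or untested is meant among the compounds shown, and "the series" means these compounds.

Compounds measured in an ADME assay on L929 cells (Mus musculus) for cytotoxicity, read by resazurin assay, with a stated time of 72 h; a lower number here means a stronger inhibitor, a higher number a weaker inhibitor:
- compound 1, `O=C(O)c1ccc(C(=O)/C=C/c2ccc3c(c2)B(O)OC3)cc1`, gives > 10 ug/mL, which is a limit of the assay.
- compound 2, `O=C(/C=C/c1ccc2c(c1)B(O)OC2)c1ccc(Br)cc1`, gives > 10 ug/mL, which is a limit of the assay.
- compound 3, `CCc1ccc(C(=O)/C=C/c2ccc3c(c2)B(O)OC3)cc1`, gives > 10 ug/mL, which is a limit of the assay.

Compound 2 therefore stands at the limit of this assay, and the two other values shown stand at the same limit (the limit of > 10 ug/mL in this assay, at which 3 of the 3 values shown sit). The piece follows the change from compound 2 to the not yet measured compound 4, `Cn1cccc1C(=O)/C=C/c1ccc2c(c1)B(O)OC2`. The change is 1-methyl-1H-pyrrol-2-yl in place of 4-bromophenyl on a carbonyl carbon.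

The measured steps that touch the same part of the shared core are a step that the two limits leave unreadable from compound 1 to compound 2, a step that the two limits leave unreadable from compound 1 to compound 3 and a step that the two limits leave unreadable from compound 2 to compound 3. None of them yields a readable size, since both ends of each sit at the limit. Among the compounds with values here, they show only that exchanging the group on this carbonyl carbon has not brought any of the three compounds to a number inside the measured range, and nothing in these steps points in either direction for compound 4.

On that basis compound 4 is expected to sit at or near the same limit, and the step from compound 2 is estimated as a step that the limit leaves unreadable from compound 2 to compound 4. The value of compound 4 in this assay is estimated at 20 ug/mL, with a range from 7 ug/mL to 60 ug/mL.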

Compound 4, half-maximal inhibitory concentration: > 10 ug/mL
Compound 4 ended at the assay's limit; the forecaster's own chance of this, stated with the estimate: 80%; the middle value does not contradict the limit.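

Compound 2 and compound 4 both sit at a limit of this assay, so no size can be read for the step between them: the limit of > 10 ug/mL in this assay, at which 4 of the 4 values shown sit.

The compounds shown leave open what actual number any of them would give in this assay, and whether changing the group on the carbonyl carbon alters that number at all.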